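This account rests on a few compounds, and the source may have more. Where it says the series, first, only, none or still open, it means among the compounds named here.

In a functional assay on LOX IMVI cells (Homo sapiens) for cytotoxicity, read by MTT assay, with a stated time of 24 h (a lower number here means a stronger inhibitor, a higher number a weaker inhibitor), compound 1 (`COc1cc(-c2nc(-c3ccccc3)[nH]c2-c2ccnc(NCCCNS(=O)(=O)c3ccc(Br)cc3)n2)ccc1F`) gives 33900 nM and compound 2 (`COc1cc(-c2nc(-c3ccccc3)[nH]c2-c2ccnc(NCCCNS(=O)(=O)c3ccc(Br)cc3)n2)ccc1Cl`) gives 23700 nM in the same test. Within the data shown here, with only these two numbers available, compound 2 stands within the scatter of its single neighbour. The measured step is a 1.4-fold lower number from compound 1 to compound 2 (0.16 log units; within the scatter) and consists of chloro in place of fluoro on an aromatic carbon. Compound 3 (`COc1ccc(S(=O)(=O)NCCCNc2nccc(-c3[nH]c(-c4ccccc4)nc3-c3ccc(Cl)c(OC)c3)n2)cc1`) differs from compound 2 by methoxy in place of bromo on an aromatic carbon, so 4-bromophenyl becomes 4-methoxyphenyl (methoxy in place of bromo on an aromatic carbon). Among the measured compounds shown here, no measurement yet tests a change at this place, since the one known step lies elsewhere on the molecule. That makes it a thin guide, and no shift beyond the scatter is expected. The estimated step is a 1.1-fold higher number from compound 2 to compound 3 (0.02 log units; within the scatter) and carries wide uncertainty. In this assay the expected value for compound 3 is 25000 nM with an estimated range from 10000 nM to 60000 nM around it.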

Compound 3, half-maximal inhibitory concentration: 1800 nM
For compound 3 the middle estimate is 14-fold (1.14 log units) above the measured one, outside the stated range (below it).
By their numbers in this assay, from the lowest: compound 3; then compounds 2 and 1 (each within the scatter of the next).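

Replacing the bromo of the 4-bromophenyl group with methoxy gives a 13-fold lower number from compound 2 to compound 3 (1.12 log units; beyond the scatter) in this assay, so this position responds strongly to a change, whereas chloro in place of fluoro elsewhere on the molecule gave only a 1.4-fold lower number from compound 1 to compound 2 (0.16 log units; within the scatter). Methoxy adds a hydrogen-bond acceptor that bromo lacks, but this single pair cannot separate that difference from the other differences between the two groups. No measured evidence here bears on what lies behind this large step.

As far as these compounds go, with only one replacement at this position, it remains open whether the drop is specific to methoxy or whether other groups, such as hydroxyl, an amine or the longer ethoxy, would behave alike. From the compounds shown here alone, it is also open whether the same drop would appear with fluoro rather than chloro at the other site.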